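The source may report more compounds than this note shows. Statements on the series, on what has been measured and on what is new or still open speak of the compounds shown alone.

Working notes on the series. Compound 1 `CN(C)C(=O)c1cc(-c2cnc(NCc3c(F)ccc4c3CCO4)c3cn[nH]c(=O)c23)n(C)n1` in a physicochemical assay for lipophilicity, using the shake flask method, in phosphate buffer, measured as octanol-water partition, with a stated time of 30 min, at pH 7.4 (on this read-out higher numbers stand for higher lipophilicity and lower numbers for lower lipophilicity), gives 2.1. Compound 2 `COCCC(=O)Nc1cnc(NCc2c(F)ccc3c2CCO3)n2cnnc12` in this assay gives 1.4. Going by the values given here, of the two numbers measured so far, compound 1 holds the highest; its nearest neighbour, compound 2, lies lower by a margin beyond the scatter. Among the compounds with values here, these two differ in more than one place, so no single step between them is computed and only their two values are noted. Compound 3 `Cc1nc(CO)ccc1-c1cnc(NCc2c(F)ccc3c2CCO3)c2cn[nH]c(=O)c12` has not yet been measured in this assay. It differs from compound 1 in one place: 6-(hydroxymethyl)-2-methylpyridin-3-yl in place of 3-(dimethylcarbamoyl)-1-methyl-1H-pyrazol-5-yl on an aromatic carbon. Within the data shown here, no step of this kind is measured, so the expected step is a number 0.20 log units higher from compound 1 to compound 3 (within the scatter), not beyond the scatter in either direction. The expected value for compound 3 in this assay is 2.3, within a range from 1.7 to 2.9.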

Compound 3, distribution coefficient: 2.4
Estimate against measurement, compound 3: 0.10 log units below, within the range that was stated.
By their numbers in this assay, from the lowest: compound 2; then compounds 1 and 3 (each within the scatter of the next).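

Going by these compounds alone, at this position, on an aromatic carbon para to a large group, 6-(hydroxymethyl)-2-methylpyridin-3-yl in place of 3-(dimethylcarbamoyl)-1-methyl-1H-pyrazol-5-yl gives in this assay a number 0.30 log units higher from compound 1 to compound 3 (within the scatter), the first step that can be read, and it does not separate the two compounds. The exchange is not a small one on paper: a five-membered aromatic ring with 2 hetero atoms and 11 heavy atoms leaves, a six-membered aromatic ring with 1 hetero atom and 9 heavy atoms enters, and 1 hydrogen-bond donor appears, yet the read-out stays within the scatter for this single pair. No measurement at hand bears on why these two groups read alike.

Since the whole group changes in one step, the shares of the hydroxymethyl, the methyl and the ring itself cannot be told apart, and a single pair sets no trend for this position. Open too, from the compounds shown here alone, is whether a group of another kind on this aromatic carbon, such as a carboxylic acid, a primary amine or a longer ether chain in place of the hydroxymethyl, would stay equally close to compound 1 or move beyond the scatter.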